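The source may hold more compounds than are shown below. What is called first, only, known or untested is meant among the compounds shown, and "the series" means these compounds.

Measured so far in an ADME assay on WI-38 cells (Homo sapiens) for inhibition, read by MTT assay, with a stated time of 72 h; a higher number here means a weaker inhibitor, a lower number a stronger inhibitor:
compound 1 `O=C(OC1(C(=O)Nc2ccc([N+](=O)[O-])cc2)CCCCC1)c1ccc(Cl)cc1` gives 355 nM
compound 2 `Cc1ccccc1C(=O)OC1(C(=O)Nc2ccc([N+](=O)[O-])cc2)CCCCC1` gives 352 nM
compound 3 `O=C(OC1(C(=O)Nc2ccc([N+](=O)[O-])cc2)CCCCC1)c1ccc(Br)cc1` gives 523 nM

Compound 1 holds the second highest of these three numbers; its nearest step is a 1.0-fold lower number from compound 1 to compound 2 (0.00 log units; within the scatter) and its furthest is a 1.5-fold higher number from compound 1 to compound 3 (0.17 log units; within the scatter), both within the scatter. Compound 4 `O=C(OC1(C(=O)Nc2ccc([N+](=O)[O-])cc2)CCCCC1)c1ccccc1` differs from compound 1 in one place: hydrogen in place of chloro on an aromatic carbon. Among the measured compounds shown here, no measured step removes this chloro outright. The two steps that alter the same ring, the change to compound 2 and the change to compound 3, each stayed within the scatter, so no step beyond the scatter is expected in this assay here either. The expected step is a 1.2-fold higher number from compound 1 to compound 4 (0.07 log units; within the scatter). Compound 4 is therefore estimated at 420 nM, with a range from 200 nM to 900 nM.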

Compound 4, half-maximal inhibitory concentration: 246 nM
Compound 4: the middle estimate sits 1.7-fold (0.23 log units) above what was measured; measured number inside the range.
By their numbers in this assay, from the lowest: compounds 4, 2, 1 and 3 (each within the scatter of the next, the first and the last beyond it).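

In this assay, among the compounds shown here, the step of a 2.1-fold lower number from compound 3 to compound 4 (0.33 log units; beyond the scatter) is the first in this set to pass the usual scatter, though only modestly, so the group on this ring can show in the number. Removing the chloro gives a 1.4-fold lower number from compound 1 to compound 4 (0.16 log units; within the scatter) and hydrogen for methyl gives a 1.4-fold lower number from compound 2 to compound 4 (0.16 log units; within the scatter), so compound 1, compound 2 and compound 4 cannot be told apart here. Nothing available explains the gap between bromo and hydrogen. From the compounds shown here alone, whether an amine or a carboxylic acid on this ring would move the number further stays open.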